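Bromo in Place of Methyl: An Expected Flat Step

This account rests on a few compounds, and the source may have more. Where it says the series, first, only, none or still open, it means among the compounds named here.

Of the compounds shown here, three measured so far share one core. Compound 1 `Fc1cccc(CSc2nc(-c3ccc(Br)cc3)cc(-c3cccc(Br)c3)n2)c1`, compound 2 `Clc1ccccc1CSc1nc(-c2ccc(Br)cc2)cc(-c2ccc(Br)cc2)n1` and compound 3 `Cc1ccc(-c2cc(-c3cccc(Br)c3)nc(SCc3ccccc3Cl)n2)cc1` were all tested in an assay on isolated protein for inhibition of Alpha glucosidase (Homo sapiens), read by spectrophotometry, with stated times of 15 min and 30 min; a lower number here means a stronger inhibitor, a higher number a weaker inhibitor. In this assay compound 1 gives 19000 nM. In this assay compound 2 gives 19000 nM. In this assay compound 3 gives 19000 nM, level with compound 1 and compound 2 at the digits reported; its nearest neighbour is compound 1 and its furthest is compound 2, and both gaps lie within the scatter. No pair among these three differs in only one place, so no single step between measured compounds can be read off.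

Compound 4 `Clc1ccccc1CSc1nc(-c2ccc(Br)cc2)cc(-c2cccc(Br)c2)n1` differs from compound 3 by bromo in place of methyl on an aromatic carbon. The two measured compounds that already carry bromo in place of such a methyl, compound 1 and compound 2, stand level with compound 3, and nothing among the three measured compounds points to a shift in either direction. The step of no change at the digits printed from compound 3 to compound 4 (within the scatter) is therefore expected to be none beyond the scatter. Compound 4 is expected to come in at 19000 nM, with a range from 9500 nM to 38000 nM.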

Compound 4, half-maximal inhibitory concentration: 19000 nM
For compound 4 middle estimate and measured number coincide at the digits printed, within the range that was stated.
By their numbers in this assay, from the lowest: compounds 1, 2, 3 and 4 (each within the scatter of the next).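

In this assay the exchange of methyl for bromo on this aromatic carbon, para to a large group, reads no change at the digits printed from compound 3 to compound 4 (within the scatter) and thus gives 4-methylphenyl and 4-bromophenyl no measurable separation at this position. Among these compounds, compound 4 also provides the first single-place comparisons at two other sites: 3-bromophenyl in place of 4-bromophenyl reads no change at the digits printed from compound 2 to compound 4 (within the scatter) and 2-chlorophenyl in place of 3-fluorophenyl on the saturated chain carbon bound to a sulfur reads no change at the digits printed from compound 1 to compound 4 (within the scatter) and so neither of these changes separates the compounds either. Nothing available accounts for these flat steps.

All four compounds carry only methyl, bromo, chloro or fluoro on these groups. On these data alone, whether an amine or a carboxylic acid in place of the bromo, or a longer chain in place of the saturated chain carbon bound to the sulfur, would shift the value remains open.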